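This account rests on a few compounds, and the source may have more. Where it says the series, first, only, none or still open, it means among the compounds named here.

For the measured compounds named here, in a functional assay on ECa-109 cells for inhibition, with ECa-109 cell line (Homo sapiens) as the target, read by sulforhodamine B assay (a higher number here means a weaker inhibitor, a lower number a stronger inhibitor), compound 2 `O=C1C=C(Nc2ccccc2F)C(=O)c2c1nc1n2[C@H]2OC[C@@H](O)[C@H]2OC1` gives 2760 nM, the only true number among the compounds measured so far. Compound 1 `CCCc1ccc(NC2=CC(=O)c3nc4n(c3C2=O)[C@H]2OC[C@@H](O)[C@H]2OC4)cc1` reports only a limit, > 4000 nM. Going by the values given here, compound 3 `O=C1C(N2CCCC2)=CC(=O)c2c1nc1n2[C@H]2OC[C@@H](O)[C@H]2OC1`, the one measured compound with no aromatic ring on its amine nitrogen, also reports only a limit, > 16000 nM.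

The next compound to consider is compound 4 `O=C1C=C(NC2CCCC2)C(=O)c2c1nc1n2[C@H]2OC[C@@H](O)[C@H]2OC1`, which has cyclopentyl in place of 2-fluorophenyl on an amine nitrogen. Among the compounds with values here, the only measured step bearing on this change is an at least 1.4-fold lower number from compound 1 to compound 2 (0.16 log units; that floor lies within the scatter). That step replaces 4-propylphenyl with 2-fluorophenyl, so one aromatic group gives way to another, and it says little about a non-aromatic group. The limit for compound 3, > 16000 nM, gives a weak hint that losing the aromatic ring may weaken inhibition. A modest move towards a higher number is therefore expected, estimated as a 2.2-fold higher number from compound 2 to compound 4 (0.34 log units; beyond the scatter). For compound 4, the estimated value is 6000 nM, with an expected range from 2000 nM to 18000 nM.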

Compound 4, half-maximal inhibitory concentration: > 16000 nM
Compound 4 ended at the assay's limit; the forecaster's own chance of this, stated with the estimate: 35%; middle value at least 2.6-fold (0.42 log units) from the limit.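

In this assay, for the compounds shown here, replacing the aromatic 2-fluorophenyl with the non-aromatic cyclopentyl on this amine nitrogen gives an at least 5.7-fold higher number from compound 2 to compound 4 (0.76 log units; beyond the scatter), the first step at this position that clearly exceeds the usual scatter. On these data alone, the result for compound 4 is a limit and not a true number, so this step gives only a minimum, and its full size stays unknown because the reading stops at that limit: the limit of > 16000 nM in this assay, at which 2 of the 4 values shown sit. The step from compound 1 to compound 4 cannot be read, as both of its ends are limits.

As far as these compounds go, only compound 2 has a true number, so it remains open whether the loss comes from removing the aromatic ring or the fluorine. An unsubstituted phenyl or a benzyl group on this nitrogen could help separate those two possibilities.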